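The compounds below may be only part of what the source reports. "The series", "measured", "known", "first", "only" and "open" are said of these compounds alone.

Three compounds sharing one core have been characterised in a physicochemical assay for lipophilicity, read by HPLC, in phosphate buffer, measured as chromatographic lipophilicity, at pH 7.4; on this read-out lower numbers stand for lower lipophilicity and higher numbers for higher lipophilicity. Compound 1 `COc1ccc2nc(C)cc(OC(C)(C)C(=O)Nc3cc(C)cc(C)c3)c2c1` gives 6.37 in this assay. Compound 2 `COc1ccc2nc(C)cc(OC3CCN(c4ccccc4)C3=O)c2c1` gives 4.99. Compound 3 `COc1ccc2nc(C)cc(OCC(=O)Nc3ccccc3)c2c1` gives 4.28, the lowest of the three numbers: compound 2 lies nearest, higher by an amount beyond the scatter, and compound 1 lies furthest, higher by a gap well beyond the scatter. Among the measured compounds shown here, no two of these measured compounds differ in a single place, so no step between them can be drawn from the data.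

The account now turns to compound 4 `COc1ccc2nc(C)cc(OCC(=O)Nc3ccc(Cl)c(OC)c3)c2c1`, which has not yet been measured. It differs from compound 3 in one place: 4-chloro-3-methoxyphenyl in place of phenyl on an amide-type nitrogen. For the measured compounds named here, with no matched step among the measured compounds to rest on, the expectation must be stated in general terms, and the author expects a rise in this assay, beyond the scatter, of about a number 0.62 log units higher from compound 3 to compound 4 (beyond the scatter). Compound 4 is therefore estimated to give roughly 4.9, with a range from 4.5 to 5.3.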

Compound 4, distribution coefficient: 5.09
Compound 4: middle estimate off by 0.19 log units, on the low side; low and high end bracket the measured number.
By their numbers in this assay, from the lowest: compound 3; then compounds 2 and 4 (each within the scatter of the next); then compound 1.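

The aryl group on the amide-type nitrogen now has its first matched step: in this assay 4-chloro-3-methoxyphenyl in place of phenyl gives a number 0.81 log units higher from compound 3 to compound 4 (beyond the scatter) with the rest of the molecule unchanged. The earlier compounds shown here, none of which differed from another in a single place, could not show that a change at this position alone moves the read-out by an amount beyond the scatter. No measured evidence bears on why the step has this size.

The compounds shown leave open how the step divides between the two new groups, as neither 4-chlorophenyl nor 3-methoxyphenyl stands alone here. They also leave open how this assay would read with an amine or a carboxylic acid on this aromatic ring.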